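The source may report more compounds than this note shows. Statements on the series, on what has been measured and on what is new or still open speak of the compounds shown alone.

Measured compounds:
compound 1, `CCOC(=O)C(=O)Nc1cccccc1=O`: 84%
compound 2, `CCCCCOC(=O)C(=O)Nc1cccccc1=O`: 57%

The read-out throughout is a functional assay on the whole organism (strain Sprague-Dawley CD) for inhibition, with Rattus norvegicus as the target, read by paw edema, at a dose of 30 mg/kg by the intraperitoneal route; on this read-out higher numbers stand for a stronger effect at the one dose given and lower numbers for a weaker effect. On the two numbers available, compound 2 stands lowest: its nearest neighbour is compound 1, and the step of a number 27 percentage points lower from compound 1 to compound 2 (beyond the scatter) lies beyond the scatter, so the lengthening of the ester chain went with a weaker result in this assay.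

Compound 3, `NNC(=O)C(=O)Nc1cccccc1=O`, has not been measured. It differs from compound 2 in one place: aminoamino in place of pentyloxy on a carbonyl carbon. Within the data shown here, no measured step involves an aminoamino group, so the only guide is the single step from compound 1 to compound 2, which shows that the shorter ester chain went with the higher number. Compound 3 removes the pentyloxy group entirely and replaces it with a group of two heavy atoms carrying two hydrogen-bond donors; the direction of such a change has not been tested here, and the expectation must be held loosely.

The step of a number 13 percentage points higher from compound 2 to compound 3 (beyond the scatter) is the estimated change on going to compound 3. Compound 3 is expected to give about 70%, within a range from 40% to 95%, in this assay.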

Compound 3, a percentage reported as inhibition, in the whole organism at one dose (the size of the read-out at that dose, not a potency): 78%
Estimate against measurement, compound 3: 8 percentage points below; low and high end bracket the measured number.
By their numbers in this assay, from the lowest: compound 2; then compounds 3 and 1 (each within the scatter of the next).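

The pentyloxy group on this carbonyl carbon can give way to a quite different group with the number recovering: in this assay, aminoamino in place of pentyloxy brings a number 21 percentage points higher from compound 2 to compound 3 (beyond the scatter). The same exchange set against the shorter ester brings a number 6 percentage points lower from compound 1 to compound 3 (within the scatter), so among these three compounds an alkoxy group at this place is not required for a strong result, and compound 3, which carries no ester at all, cannot be separated from compound 1 on this read-out. Nothing available bears on why the number moves with these exchanges.

From the compounds shown here alone, what a carboxylic acid, a plain amine or a methoxy group would give on the same carbonyl carbon stays open, as does whether the drop seen with the longer ester chain runs gradually through propoxy and butoxy chains or appears only at pentyloxy. The read-out also gives the size of the effect at one dose only, so these compounds leave open how their potencies would compare across a range of doses.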